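A few compounds are considered here, and "the series" means these few. Any claim that something is new, unique, unknown or untested is made for them only; others in the source may bear on it.

Compound 1, with the structure `COC(=O)/C=C/c1cccc(N(Cc2ccc(-c3cccc(C)c3)cc2)C(=O)C2CCCCC2)c1`, is the starting point. In an assay on isolated protein with Bile acid receptor (Homo sapiens) as the target (a lower number here means that less compound is needed, a higher number that more compound is needed for the effect), compound 1 gives 109 nM, the lowest of the two numbers at hand. Its nearest neighbour is compound 2, `COC(=O)/C=C/c1cccc(N(Cc2ccc(-c3cccc(C)c3)cc2)C(=O)C(C)C)c1`, which in this assay gives 163 nM; the step of a 1.5-fold higher number from compound 1 to compound 2 (0.17 log units; within the scatter) stays within the scatter. Compound 3, `CCOC(=O)COc1cc(/C=C/C(=O)OC(C)(C)C)ccc1CN(C(=O)C1CCCCC1)c1cccc(/C=C/C(=O)OC)c1`, reaches only a limit of the assay, > 1000 nM, and the single entry at the limit of > 1000 nM in this assay, at which 1 of the 3 values shown sits, is that limit rather than a number.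

The compound not yet measured is compound 4, `COC(=O)/C=C/c1cccc(N(Cc2ccc(/C=C/c3ccc(OC)cc3)cc2)C(=O)C2CCCCC2)c1`. It differs from compound 1 in one place: 2-(4-methoxyphenyl)ethenyl in place of 3-methylphenyl on an aromatic carbon. Within the data shown here, none of the measured steps touches that place. Among the measured compounds shown here, the only step between single-change neighbours, from compound 1 to compound 2, alters the group on the carbonyl carbon and stays within the scatter, so it says nothing about the aromatic end that is changed here. Compound 3 differs from compound 1 in several places at once and gives only a limit, so it offers no guide either. A step of no clear direction beyond the scatter is therefore the expectation, with a wide margin. For compound 4 in this assay the estimate is 150 nM, with a range from 40 nM to 600 nM. That amounts to an expected step of a 1.4-fold higher number from compound 1 to compound 4 (0.14 log units; within the scatter).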

Compound 4, half-maximal effective concentration: 208 nM
The estimate for compound 4 lay 1.4-fold (0.14 log units) below the measured number; low and high end bracket the measured number.
By their numbers in this assay, from the lowest: compounds 1, 2 and 4 (each within the scatter of the next). At a limit, above all of these: compound 3.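

Until now the place on the aromatic carbon that holds 3-methylphenyl in compound 1 had no reading of its own. In this assay, putting 2-(4-methoxyphenyl)ethenyl there gives a 1.9-fold higher number from compound 1 to compound 4 (0.28 log units; within the scatter) and so no difference that can be told apart from repeat measurement. This is informative in itself: the entering group has 10 heavy atoms where the leaving group has 7, it adds a double bond outside aromatic rings and a hydrogen-bond acceptor, and the assay still does not separate the two compounds, so for this one pair a larger group at this place costs nothing the measurement can resolve, though a single swap sets no rule for other groups.

Going by these compounds, the ethenyl link and the methoxy group enter together, so their separate shares stay open, as does whether this place would accept an amine, a carboxylic acid or a plain hydrogen in place of an aromatic ring. Nothing measured on these compounds speaks to why the number stays where it does.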